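A few compounds are considered here, and "the series" means these few. Any claim that something is new, unique, unknown or untested is made for them only; others in the source may bear on it.

Compound 1 `CN1CCc2nc(C#Cc3ccccc3)sc2C1` carries a methyl on the amine nitrogen in the ring, and in an assay on HEK293 cells for positive allosteric modulation of metabotropic glutamate receptor 5 (Homo sapiens), read by FLIPR, with a stated time of 1 h (a higher number here means that more compound is needed for the effect, a lower number that less compound is needed), compound 1 gives 34 nM. Compound 2 `CCN1CCc2nc(C#Cc3ccccc3)sc2C1` differs from it only by methyl in place of hydrogen on a saturated chain carbon bound to an amine nitrogen in a ring, so the methyl has grown into an ethyl. In this assay compound 2 reaches only a limit, > 10000 nM, not a measured number. Among the compounds with values here, the step of an at least 290-fold higher number from compound 1 to compound 2 (2.46 log units; beyond the scatter) is the only measured step here, and it shows that this position tolerates little change. Compound 3 `O=C(C1CCCO1)N1CCc2nc(C#Cc3ccccc3)sc2C1` carries (oxolan-2-yl)carbonyl in place of ethyl on an amine nitrogen in a ring. Within the data shown here, no measured step covers a carbonyl on this nitrogen, so an at least 290-fold higher number from compound 1 to compound 2 (2.46 log units; beyond the scatter) is the sole guide, and it points to compound 3 staying at the limit of > 10000 nM in this assay, at which 1 of the 2 values shown sits. Compound 3 is therefore expected to show a number no higher from compound 2 to compound 3 (the limit leaves the size open). Compound 3 is estimated at 10000 nM, between 1500 nM and 40000 nM.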

Compound 3, half-maximal effective concentration: 790 nM
Estimate against measurement, compound 3: 13-fold (1.10 log units) above, outside the stated range (below it).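

The amine nitrogen in the ring does not simply turn away every group larger than methyl. In this assay there is an at least 12-fold lower number from compound 2 to compound 3 (1.10 log units; beyond the scatter), although the (oxolan-2-yl)carbonyl that enters has more heavy atoms than the ethyl that leaves, so among these compounds the count of heavy atoms alone does not set the result. Methyl still gives the lower number, with a 23-fold higher number from compound 1 to compound 3 (1.37 log units; beyond the scatter), and compound 2 alone stands at a limit and not at a measured number: the limit of > 10000 nM in this assay, at which 1 of the 3 values shown sits.

On these data alone, what remains open is whether the gain belongs to the carbonyl or to the oxolane ring, as both enter in one change. An acetyl group on this nitrogen would carry the carbonyl without the ring, and a tetrahydrofuranylmethyl group would carry the ring without the carbonyl.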